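The compounds below may be only part of what the source reports. "The series", "measured", "known", "first", "only" and "open" are said of these compounds alone.

Measured compounds:
compound 1, `COc1cc(/C=C/C2CC(=O)C=CO2)cc(OC)c1OC`: 127 uM
compound 2, `COc1ccc(/C=C/C2CC=CC(=O)O2)cc1OC`: 14.6 uM
compound 3, `COc1cc(/C=C/C2CC=CC(=O)O2)cc(OC)c1`: 9 uM

In a functional assay on NCI-H460 cells (Homo sapiens) for inhibition, read by sulforhodamine B assay, with a stated time of 48 h (a higher number here means a weaker inhibitor of growth, a lower number a stronger inhibitor of growth), compound 3 gives the lowest of the three numbers. Compound 2 sits within the scatter of compound 3, so no order between these two can be read. Compound 1, which carries a different core, gives a number beyond the scatter from compound 3.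

Compound 4, `COc1cc(/C=C/C2CC=CC(=O)O2)cc(OC)c1OC`, keeps the core of compound 3 and differs from it by methoxy in place of hydrogen on an aromatic carbon. Among the measured compounds shown here, no step between measured compounds shows this change, so the expectation rests only on the closeness of compound 2 and compound 3, which suggests that a further change in the aryl substitution leaves the number in this assay little moved. The expected step from compound 3 to compound 4, a 1.7-fold higher number from compound 3 to compound 4 (0.22 log units; within the scatter), is small, leaning toward a higher number and probably within the scatter. Compound 4 is therefore estimated at 15 uM, with a range of 5 uM to 50 uM.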

Compound 4, concentration for growth inhibition (reported as GI): 28.8 uM
The estimate for compound 4 lay 1.9-fold (0.28 log units) below the measured number, and the stated range covers the measured number.
By their numbers in this assay, from the lowest: compounds 3, 2 and 4 (each within the scatter of the next, the first and the last beyond it); then compound 1.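

In this assay, methoxy in place of hydrogen on the aromatic carbon ortho to two methoxy groups and para to a group of 9 heavy atoms gives a 3.2-fold higher number from compound 3 to compound 4 (0.51 log units; beyond the scatter) at this position, whereas the same exchange on another aromatic carbon gives a 2.0-fold higher number from compound 2 to compound 4 (0.30 log units; within the scatter) and so shows no readable change. With the aryl substitution held constant, the core exchange gives a 4.4-fold lower number from compound 1 to compound 4 (0.64 log units; beyond the scatter) as the first single-place measure of the core. On these data alone, whether hydroxy, fluorine or an amine at this position would behave like methoxy stays open. Nothing measured here bears on the cause of these steps.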